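Ring Expansion on a Shared Core at the Assay Limit

The compounds below may be only part of what the source reports. "The series", "measured", "known", "first", "only" and "open" are said of these compounds alone.

Compound 1 `CS(=O)(=O)c1ccc(C(=O)N2CCC(C(=O)N3CCc4ccccc43)CC2)cc1[N+](=O)[O-]` was tested in an assay on isolated protein for inhibition of thyroid hormone receptor beta (Homo sapiens), read by fluorescence polarization (a lower number here means a stronger inhibitor, a higher number a weaker inhibitor), where compound 1 gives > 60000 nM, which is a limit of the assay rather than a number. Compound 2 `CN(CC(=O)N(Cc1ccccc1)Cc1ccccc1)C(=O)c1ccc(S(C)(=O)=O)c([N+](=O)[O-])c1` likewise gives only a limit, > 60000 nM. Compound 3 `CN1CCN(C(=O)CNC(=O)c2ccc(S(C)(=O)=O)c([N+](=O)[O-])c2)CC1` also gives only a limit, > 60000 nM. Compound 1 thus sits at the limit of > 60000 nM in this assay, at which 3 of the 3 values shown sit, with no measured number to place it against the others. Compound 4 `CS(=O)(=O)c1ccc(C(=O)N2CCC(C(=O)N3CCc4ccccc4C3)CC2)cc1[N+](=O)[O-]` differs from compound 1 in one place: 1,2,3,4-tetrahydroisoquinolin-2-yl in place of 2,3-dihydro-1H-indol-1-yl on a carbonyl carbon. Among the measured compounds shown here, no measured pair shows this change, so its effect is unknown. All three values shown are limits. The expected step that the limit leaves unreadable from compound 1 to compound 4 is none beyond the scatter. Compound 4 is accordingly expected to give 100000 nM in this assay, with a likely range from 30000 nM to 300000 nM, most probably reported again as a limit.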

Compound 4, half-maximal inhibitory concentration: > 60000 nM
Compound 4: no number, only a limit; the forecaster's own chance of this, stated with the estimate: 85%; the middle value is on the limit's open side.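

Among the compounds shown here, neither compound 1 nor compound 4 gives a number in this assay, so no step between them can be read. The compounds shown leave open which structural change, if any, would give a measurable value, as all remain at the limit: the limit of > 60000 nM in this assay, at which 4 of the 4 values shown sit.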